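Notes on compound 4, taken from compound 2

The source may hold more compounds than are shown below. What is called first, only, known or untested is meant among the compounds shown, and "the series" means these compounds.

The series is followed in an assay on isolated protein for inhibition of malate dehydrogenase, mitochondrial (Sus scrofa), with stated times of 45 min and 30 min; on this read-out lower numbers stand for stronger inhibition and higher numbers for weaker inhibition. Compound 1 `Cc1ccccc1S(=O)(=O)Nc1ccc2oc(-c3ccccc3)nc2c1` gives only a limit of the assay, > 63000 nM. Compound 3 `Cc1ccc(S(=O)(=O)Nc2ccc3oc(-c4ccccc4)nc3c2)cc1` likewise reaches only a limit, > 63000 nM. Going by the values given here, the single step between measured compounds that differ in one place, a step that the two limits leave unreadable from compound 1 to compound 3, therefore cannot be read. Compound 2 `C=Cc1ccc(S(=O)(=O)Nc2ccc(-c3nc4ccccc4o3)cc2)cc1` also stands at a limit, > 63000 nM. All values shown sit at that bound, (the limit of > 63000 nM in this assay, at which 3 of the 3 values shown sit).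

Compound 4 `O=S(=O)(Nc1ccc(-c2nc3ccccc3o2)cc1)c1ccc(O)cc1` differs from compound 2 in one place: hydroxy in place of vinyl on an aromatic carbon. Among the compounds with values here, no measured step covers this change; the only step recorded is unreadable, so neither direction nor size can be drawn from the series. With every measured value at the bound, the expectation is that compound 4 will again fall at or near the limit. The expected step is a step that the limit leaves unreadable from compound 2 to compound 4, nothing beyond the scatter. Compound 4 is estimated at 70000 nM, with a range from 20000 nM to 250000 nM, and most likely reported only as a limit.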

Compound 4, half-maximal inhibitory concentration: > 63000 nM
Compound 4 ended at the assay's limit; the forecaster's own chance of this, stated with the estimate: 80%; the middle value lies beyond the limit too.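

No new step can be read: compound 2 and compound 4 both stand at a limit, so the change between them shows neither direction nor size. The compounds shown leave open what structure, if any, gives a readable value in this assay, since every value sits at one bound: the limit of > 63000 nM in this assay, at which 4 of the 4 values shown sit.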